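A Chlorine Added to the Least Active Analogue

The compounds below may be only part of what the source reports. "The series", "measured", "known", "first", "only" and "open" are said of these compounds alone.

Of the compounds shown here, three built on one shared core have been tested in a functional assay on U-87MG ATCC cells for antiproliferative activity against U-87 MG (Homo sapiens), read by MTT assay, with a stated time of 48 h, tested at 10 uM; a lower number here means a stronger effect, a higher number a weaker effect of the compound at the concentration tested. Compound 1 `Cc1nc(-c2ccc(Cl)cc2)sc1C(=O)CSc1nc(-c2ccc(Cl)c(Cl)c2)c(C#N)c(=O)[nH]1` gives 97.1% in this assay, compound 2 `Cc1nc(-c2ccccc2)sc1C(=O)CSc1nc(-c2ccccc2)c(C#N)c(=O)[nH]1` gives 87.5%, and compound 3 `COc1ccc(-c2nc(SCC(=O)c3sc(-c4ccccc4)nc3C)[nH]c(=O)c2C#N)cc1OC` gives 69.8%. Compound 3 therefore stands lowest of the three, and its distance to each of the others lies beyond the usual scatter. Going by the values given here, only one pair differs in a single place: the change a number 17.7 percentage points lower from compound 2 to compound 3 (beyond the scatter) is a 3,4-dimethoxyphenyl in place of phenyl on an aromatic carbon.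

Compound 4 `COc1ccc(-c2nc(SCC(=O)c3sc(-c4ccc(Cl)cc4)nc3C)[nH]c(=O)c2C#N)cc1OC` differs from compound 3 by chloro in place of hydrogen on an aromatic carbon. Among the compounds with values here, no measured pair differs by exactly this change. Compound 1 and compound 2 differ in two places, one of them the same phenyl to 4-chlorophenyl exchange, and their values show compound 1 at 97.1% against compound 2 at 87.5%, a gap that cannot be assigned to either place. Within the data shown here, with no direct precedent, the step of a number 4.2 percentage points higher from compound 3 to compound 4 (within the scatter) is expected to stay within the scatter, leaning if anything slightly upward. Compound 4 is thus estimated at 74% in this assay, with a likely range from 58% to 90%.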

Compound 4, a percentage reported as activity, at one concentration (the size of the read-out at that concentration, not a potency): 83.3%
Compound 4: middle estimate off by 9.3 percentage points, on the low side; the measured number falls inside the stated range.
By their numbers in this assay, from the lowest: compound 3; then compounds 4, 2 and 1 (each within the scatter of the next, the first and the last beyond it).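

In this assay, going by these compounds alone, the exchange of phenyl for 4-chlorophenyl can now be read on its own: chloro in place of hydrogen gives a number 13.5 percentage points higher from compound 3 to compound 4 (beyond the scatter), a weaker effect at the concentration tested, whereas the earlier compounds offered this exchange only mixed with a second change. With the 4-chlorophenyl held fixed, the other end of the molecule also gains a new comparison: 3,4-dimethoxyphenyl in place of 3,4-dichlorophenyl gives a number 13.8 percentage points lower from compound 1 to compound 4 (beyond the scatter), so the dimethoxy group carries the lower number here, just as it did against plain phenyl in a number 17.7 percentage points lower from compound 2 to compound 3 (beyond the scatter), and neither single-change comparison of that aryl group goes against this. The data at hand offer nothing that explains either step.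

Going by these compounds, the chloro step is known only with 3,4-dimethoxyphenyl at the other end of the molecule, so its size alongside a plain phenyl or a 3,4-dichlorophenyl there remains open. Also open, on these data alone, is how a fluoro, a methoxy or an amine would compare with the chloro at the same place on the ring.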